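The compounds below may be only part of what the source reports. "The series", "measured", "known", "first", "only" and "open" are said of these compounds alone.

Measured so far in a functional assay on MCF7 cells (Homo sapiens) for cytotoxicity, in the presence of a further agent that is not named here; a lower number here means that less compound is needed, a higher number that more compound is needed for the effect:
- compound 1 `CCCCCCCO[C@@H]1[C@@H](OCc2ccccc2)[C@@H](OCc2ccccc2)O[C@H](C=C(C)C)[C@H]1OCc1ccc(OC)cc1`: > 20 ug/mL, a limit
- compound 2 `CCCCCCCO[C@@H]1[C@@H](OCc2ccccc2)[C@@H](OCc2ccccc2)O[C@H](CC(C)C)[C@H]1OCc1ccc(OC)cc1`: > 20 ug/mL, a limit

Compound 2 gives only a limit, > 20 ug/mL, and not a number. Among the measured compounds shown here, the series so far offers no number at all: the limit of > 20 ug/mL in this assay, at which 2 of the 2 values shown sit.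

Next is compound 3 `CCCCCCCO[C@H]1[C@H](O)[C@@H](CC(C)C)O[C@H](OCc2ccccc2)[C@@H]1OCc1ccccc1`. The change is hydrogen in place of 4-methoxybenzyl on an oxygen on a saturated carbon, or (4-methoxybenzyl)oxy to hydroxy.

For the measured compounds named here, the only measured step, a step that the two limits leave unreadable from compound 1 to compound 2, concerns the isobutyl group and not the 4-methoxybenzyl group, and it has no readable size. Going by the values given here, no measured step therefore bears on this change, and no step beyond the scatter is expected in this assay. The estimated step is a number no higher from compound 2 to compound 3 (the limit leaves the size open). For compound 3 the expected value is 20 ug/mL, with an estimated range of 8 ug/mL to 35 ug/mL.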

Compound 3, half-maximal effective concentration: 6 ug/mL
Compound 3: the middle estimate sits 3.3-fold (0.52 log units) above what was measured; the measured number lies below the stated range.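

In this assay, among the compounds shown here, hydrogen in place of 4-methoxybenzyl on this oxygen gives an at least 3.3-fold lower number from compound 2 to compound 3 (0.52 log units; beyond the scatter), the first readable change and the first sign that this position affects the read-out. As far as these compounds go, compound 2 gives > 20 ug/mL, which is a limit, so the printed size is a lower bound and the full size of the step stays open. The step from compound 1 to compound 2 cannot be read, and compound 3 alone carries a number: the limit of > 20 ug/mL in this assay, at which 2 of the 3 values shown sit.

From the compounds shown here alone, whether the lower number follows from the free hydroxy or from the loss of the 4-methoxybenzyl group remains open, and a methoxy group or an amine at this position would help separate the two. Also open, going by these compounds, is whether isobutyl and 2-methylprop-1-en-1-yl differ once the hydroxy is present.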